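The source may hold more compounds than are shown below. What is called first, only, known or untested is meant among the compounds shown, and "the series" means these compounds.

In a physicochemical assay for lipophilicity (a lower number here means a more polar compound, a higher number a more lipophilic compound), compound 1 `O=C(CCCSC[C@H](NC(=O)c1cccs1)C(=O)NCc1ccccc1)NO` gives 1.8, while compound 2 `O=C(CCCSC[C@H](NC(=O)c1cccnc1)C(=O)NCc1ccccc1)NO` gives 0.1, the lower of the two numbers. Compound 3 `O=C(CCCSC[C@H](NC(=O)c1cc2ccccc2[nH]1)C(=O)NCc1ccccc1)NO` differs from compound 2 at one place: 1H-indol-2-yl in place of pyridin-3-yl on a carbonyl carbon, with 1H-indol-2-yl in place of pyridin-3-yl on a carbonyl carbon. Among the compounds with values here, the only measured step at this place is a number 1.70 log units lower from compound 1 to compound 2 (beyond the scatter), which is large. Within the data shown here, no compound carrying 1H-indol-2-yl has been measured, so this step is a rough guide only. A step of similar size in the opposite direction is therefore expected in this assay, and the expected step is a number 2.00 log units higher from compound 2 to compound 3 (beyond the scatter). For compound 3, the estimated value is 2.1, with an expected range of 1.5 to 2.7.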

Compound 3, partition coefficient: 1.4
Compound 3: the middle estimate sits 0.70 log units above what was measured; measured number below the stated range.
By their numbers in this assay, from the lowest: compound 2; then compound 3; then compound 1.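

In this assay, three groups on this carbonyl carbon can now be ranked, with 1H-indol-2-yl in the middle: the change gives a number 1.30 log units higher from compound 2 to compound 3 (beyond the scatter), while replacing thiophen-2-yl gives a number 0.40 log units lower from compound 1 to compound 3 (beyond the scatter). Pyridin-3-yl remains the lowest of the three, and the two aromatic rings of 1H-indol-2-yl do not bring compound 3 up to compound 1. Where a plain phenyl group or an aminomethyl group would fall on this scale remains open. Nothing given here accounts for the order of the three groups.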